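The source may report more compounds than this note shows. Statements on the series, on what has been measured and on what is new or still open speak of the compounds shown alone.

Measured in a functional assay on CNE-2 cells (Homo sapiens) for antiproliferative activity, read by sulforhodamine B assay, with a stated time of 48 h; a higher number here means a weaker inhibitor, a lower number a stronger inhibitor:
- Compound 1 `COc1ccc(C=C(C(=O)/C=C/c2cccc(OC)c2OC)C(=O)/C=C/c2cccc(OC)c2OC)cc1OC`: 280 nM
- Compound 2 `COc1cc(OC)c(C=C(C(=O)/C=C/c2cccc(OC)c2OC)C(=O)/C=C/c2cccc(OC)c2OC)c(OC)c1`: 630 nM
- Compound 3 `COc1cccc(C=C(C(=O)/C=C/c2cccc(OC)c2OC)C(=O)/C=C/c2cccc(OC)c2OC)c1OC`: 400 nM

Compound 3 cannot be separated from either of the other two, since the numbers show a 1.4-fold higher number from compound 1 to compound 3 (0.15 log units; within the scatter) and a 1.6-fold lower number from compound 2 to compound 3 (0.20 log units; within the scatter). The next compound, compound 4 `COc1cc(C=C(C(=O)/C=C/c2cccc(OC)c2OC)C(=O)/C=C/c2cccc(OC)c2OC)cc(Br)c1O`, keeps the shared core and changes one aryl group: 3-bromo-4-hydroxy-5-methoxyphenyl in place of 2,3-dimethoxyphenyl on a double-bonded chain carbon bound to a double-bonded chain carbon.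

All three measured steps swap the aryl group at this same place. The largest is a 2.3-fold higher number from compound 1 to compound 2 (0.35 log units; beyond the scatter), a modest change, and the other two stay within the scatter. Among the measured compounds shown here, no measured compound carries the incoming group, so the data offer no direct reading of it. Only a small change in this assay is therefore expected, with no confident direction. The estimated step is a 1.1-fold higher number from compound 3 to compound 4 (0.05 log units; within the scatter). For compound 4 the expected value is 450 nM. The estimated range for compound 4 runs from 150 nM to 1300 nM.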

Compound 4, half-maximal inhibitory concentration: 220 nM
Beside the measured number, compound 4's estimate is 2.0-fold (0.31 log units) above it; low and high end bracket the measured number.
By their numbers in this assay, from the lowest: compounds 4, 1, 3 and 2 (each within the scatter of the next, the first and the last beyond it).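

In this assay, the 3-bromo-4-hydroxy-5-methoxyphenyl group brings the first bromine and the first hydrogen-bond donor to this place, yet the numbers show a 1.8-fold lower number from compound 3 to compound 4 (0.26 log units; within the scatter) and a 1.3-fold lower number from compound 1 to compound 4 (0.10 log units; within the scatter) and leave compound 4 inseparable from both dimethoxyphenyl compounds. Against the 2,4,6-trimethoxyphenyl group, the same incoming group gives a 2.9-fold lower number from compound 2 to compound 4 (0.46 log units; beyond the scatter) as a modest step, which shows that this place accepts a bromine and a hydroxyl on the ring without any loss against compound 1 or compound 3. Nothing measured here explains this result.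

Bromine and hydroxyl enter together in compound 4, and the compounds shown do not tell which of them, if either, matters. Also open, on these data alone, is how this place would respond to a ring carrying an amine or a carboxylic acid.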